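Swapping the aryl group on the imidazole nitrogen

The compounds below may be only part of what the source reports. "The series", "measured", "known", "first", "only" and "open" are said of these compounds alone.

Measured compounds:
- compound 1, `COc1cc2c(Oc3ccc(NC(=O)c4cn(-c5ccccc5OC)cn4)cc3F)ccnc2cc1OCCCN1CCN(C)CC1`: 220 nM
- compound 2, `COc1cc2c(Oc3ccc(NC(=O)c4cn(-c5cc(C)ccc5C)cn4)cc3F)ccnc2cc1OCCCN1CCN(C)CC1`: 650 nM

In a functional assay on MKN-45 cells (Homo sapiens) for cytotoxicity, read by MTT assay, with a stated time of 72 h (a lower number here means a stronger inhibitor, a higher number a weaker inhibitor), compound 2 stands with the highest of the two numbers, compound 1 giving 220 nM. Among the compounds with values here, the only measured step, a 3.0-fold higher number from compound 1 to compound 2 (0.47 log units; beyond the scatter), concerns a different swap on the same ring nitrogen. Compound 3, `COc1cc2c(Oc3ccc(NC(=O)c4cn(-c5ccc(Cl)cc5)cn4)cc3F)ccnc2cc1OCCCN1CCN(C)CC1`, carries the change (4-chlorophenyl in place of 2,5-dimethylphenyl on an aromatic nitrogen). Nothing measured directly bears on a 4-chlorophenyl group, so the expected step of a 1.6-fold lower number from compound 2 to compound 3 (0.21 log units; within the scatter) is small and its direction uncertain. For compound 3 the estimated value in this assay is 400 nM, with a range from 120 nM to 1300 nM.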

Compound 3, half-maximal inhibitory concentration: 4110 nM
Compound 3: the middle estimate sits 10-fold (1.01 log units) below what was measured, outside the stated range (above it).
By their numbers in this assay, from the lowest: compound 1; then compound 2; then compound 3.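

The aryl group on this aromatic nitrogen matters more than the first pair suggested: in this assay 4-chlorophenyl brings a 6.3-fold higher number from compound 2 to compound 3 (0.80 log units; beyond the scatter) and also a 19-fold higher number from compound 1 to compound 3 (1.27 log units; beyond the scatter). Compound 3 is therefore the weakest inhibitor of the three, so this change costs far more than the swap between the two other aryl groups. Nothing available explains this loss.

Whether the chlorine itself or the absence of the methyl and methoxy groups accounts for the loss stays open. As far as these compounds go, how an unsubstituted phenyl or a 4-aminophenyl group would read at this nitrogen also remains unknown.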